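Swapping one ring atom in a thiosemicarbazide series

The source may hold more compounds than are shown below. What is called first, only, known or untested is meant among the compounds shown, and "the series" means these compounds.

Of the compounds shown here, three have been tested in a functional assay on MCF7 cells (Homo sapiens) for cytotoxicity, read by MTT assay, with a stated time of 72 h, tested at 3 uM; a higher number here means more inhibition of growth at the concentration tested, a lower number less inhibition of growth. Compound 1 `Cc1ccnc(/C(N)=N/NC(=S)N2CCOCC2)c1` gives 5.07%, compound 2 `Cc1ccnc(/C(N)=N/NC(=S)N2CCSCC2)c1` gives 33.8%, and compound 3 `N/C(=N\NC(=S)N1CCSCC1)c1ccc(F)cn1` gives 35.4%. Compound 1 and compound 2 share a core and differ in one place, (morpholin-4-yl in place of thiomorpholin-4-yl on a thiocarbonyl carbon), a change that produced a number 28.7 percentage points lower from compound 2 to compound 1 (beyond the scatter) in this assay. Compound 2 and compound 3 carry different cores; how the two cores differ is not broken down here, and their values lie within the usual scatter of each other. The unmeasured compound 4 `N/C(=N\NC(=S)N1CCOCC1)c1ccc(F)cn1` arises from compound 3 by the same change, (morpholin-4-yl in place of thiomorpholin-4-yl on a thiocarbonyl carbon). Because the same change gave a number 28.7 percentage points lower from compound 2 to compound 1 (beyond the scatter), compound 4 is expected to show a number 27.4 percentage points lower from compound 3 to compound 4 (beyond the scatter) in this assay. The estimated value for compound 4 is therefore 8%, with a range from -5% to 22%.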

Compound 4, percent growth inhibition at one concentration: 33.9%
For compound 4 the middle estimate is 25.9 percentage points below the measured one; measured number outside the range, above it.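

In this assay, putting morpholin-4-yl in place of thiomorpholin-4-yl gives a number 1.5 percentage points lower from compound 3 to compound 4 (within the scatter), so on this core the two rings cannot be told apart. The swap therefore does not carry over unchanged from one core to the other: the same change on two cores in this assay, a number 28.7 percentage points lower (beyond the scatter) from compound 2 to compound 1 and a number 1.5 percentage points lower (within the scatter) from compound 3 to compound 4, 27.2 percentage points apart, beyond the scatter of two such steps This shows that the result of the swap depends on the core that carries it, but two pairs do not show which part of the cores matters or what the swap would do on a third core.

Going by these compounds, what in the two cores separates the outcomes remains open. So does whether an open-chain amine, such as a dimethylamino group, on the thiocarbonyl carbon would follow either ring.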